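A few compounds are considered here, and "the series" means these few. Any claim that something is new, unique, unknown or untested is made for them only; others in the source may bear on it.

Compound 1 `CCCCNc1nc(N)nc2c1CN(Cc1cccc3ccccc13)CC2`: 0.43 uM
Compound 2 `CCCCNc1nc(N)nc2c1CN(Cc1cccnc1)CC2`: 0.13 uM
Compound 3 `CCCCNc1nc(N)nc2c1CN(C(=O)CC)CC2`: 0.4 uM

In an assay on HEK293 cells for agonist activity at Toll-like receptor 8 (Homo sapiens), read by a luciferase reporter, with a stated time of 6 h (on this read-out lower numbers stand for an effect already at smaller amounts and higher numbers for an effect only at larger amounts of compound), compound 3 gives 0.4 uM, the second highest of the three numbers. Compound 1 gives 0.43 uM, which lies within the scatter of that. Among the compounds with values here, compound 2 gives 0.13 uM, the lowest number measured so far.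

Within the data shown here, the one measured step is a 3.1-fold higher number from compound 2 to compound 3 (0.49 log units; beyond the scatter), a swap on the ring nitrogen. Compound 4 `CCCCNc1nc(N)nc2c1CN(C(=O)c1cc(C)on1)CC2` differs from compound 3 in another spot: 5-methyl-1,2-oxazol-3-yl in place of ethyl on a carbonyl carbon. Among the measured compounds shown here, no measured step changes a group on a carbonyl carbon, so that step bears only loosely here. Compound 4 is expected to show a 2.0-fold lower number from compound 3 to compound 4 (0.30 log units; within the scatter), a modest lowering that stays close to the measured range. Compound 4 is estimated at 0.2 uM, between 0.06 uM and 0.7 uM.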

Compound 4, minimum effective concentration: 0.4 uM
For compound 4 the middle estimate is 2.0-fold (0.30 log units) below the measured one, within the range that was stated.
By their numbers in this assay, from the lowest: compound 2; then compounds 3, 4 and 1 (each within the scatter of the next).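

On a carbonyl carbon, swapping ethyl for 5-methyl-1,2-oxazol-3-yl brings in a five-membered aromatic ring, yet this assay shows no change at the digits printed from compound 3 to compound 4 (within the scatter), so this position takes either group with no change beyond the scatter. Replacing (pyridin-3-yl)methyl on the ring nitrogen with the new carbonyl group gives a 3.1-fold higher number from compound 2 to compound 4 (0.49 log units; beyond the scatter), the same size of step as the propanoyl swap gave. Nothing available explains why the two carbonyl groups read alike. From the compounds shown here alone, whether a longer chain or an amine on that carbonyl carbon would shift the number remains open.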